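From 2,4-dimethylphenyl to 2-chlorophenyl on an aromatic nitrogen

The source may hold more compounds than are shown below. What is called first, only, known or untested is meant among the compounds shown, and "the series" means these compounds.

Measured so far in a functional assay on A549 cells (Homo sapiens) for inhibition, read by MTT assay, with a stated time of 72 h; a higher number here means a weaker inhibitor, a lower number a stronger inhibitor
Compound 1 (`Cc1cc2occ(-c3nc(-c4ccccc4)c(-c4ccccc4)n3-c3ccc([N+](=O)[O-])cc3)c(=O)c2cc1Cl`) gives 3130 nM
Compound 2 (`COc1ccccc1-n1c(-c2coc3cc(C)c(Cl)cc3c2=O)nc(-c2ccccc2)c1-c1ccccc1`) gives 12500 nM
Compound 3 (`Cc1ccc(-n2c(-c3coc4cc(C)c(Cl)cc4c3=O)nc(-c3ccccc3)c2-c2ccccc2)c(C)c1`) gives 6250 nM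

Compound 3 lies within the scatter of both other measured compounds (a 2.0-fold higher number from compound 1 to compound 3 (0.30 log units; within the scatter)) and (a 2.0-fold lower number from compound 2 to compound 3 (0.30 log units; within the scatter)). Compound 4 (`Cc1cc2occ(-c3nc(-c4ccccc4)c(-c4ccccc4)n3-c3ccccc3Cl)c(=O)c2cc1Cl`) carries 2-chlorophenyl in place of 2,4-dimethylphenyl on an aromatic nitrogen. All three measured steps are changes at this same place, but none involves 2-chlorophenyl, so they offer only a loose guide. The largest of them is modest (a 4.0-fold higher number from compound 1 to compound 2 (0.60 log units; beyond the scatter)), so no step beyond the scatter is expected in this assay here. The expected step is small (a 1.0-fold lower number from compound 3 to compound 4 (0.02 log units; within the scatter)). Compound 4 is estimated at 6000 nM (expected range 2500 nM to 14000 nM).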

Compound 4, half-maximal inhibitory concentration: 12500 nM
Estimate against measurement, compound 4: 2.1-fold (0.32 log units) below; low and high end bracket the measured number.
By their numbers in this assay, from the lowest: compounds 1, 3, 2 and 4 (each within the scatter of the next, the first and the last beyond it).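

In this assay, 2-chlorophenyl in place of 2,4-dimethylphenyl on the aromatic nitrogen gives a step within the scatter (a 2.0-fold higher number from compound 3 to compound 4 (0.30 log units; within the scatter)), and chloro in place of methoxy on the same phenyl ring gives none (no change at the digits printed from compound 2 to compound 4 (within the scatter)). Among these compounds, the only step beyond the scatter among the new ones again starts from the 4-nitrophenyl compound (a 4.0-fold higher number from compound 1 to compound 4 (0.60 log units; beyond the scatter)), matching in size the earlier one (a 4.0-fold higher number from compound 1 to compound 2 (0.60 log units; beyond the scatter)). Nothing available explains these steps. From the compounds shown here alone, whether an amine or a carboxylic acid on this phenyl ring would shift the number remains open.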